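This account rests on a few compounds, and the source may have more. Where it says the series, first, only, none or still open, it means among the compounds named here.

The measured compounds:

Compound 1, `COc1cc(O)c(C(=O)/C=C/c2cc(OC)c(OC)c(OC)c2)cc1OC`. In an ADME assay on THP-1 cells (Homo sapiens) for cytotoxicity, read by MTT assay (on this read-out higher numbers stand for lower toxicity in this test and lower numbers for higher toxicity in this test), compound 1 gives > 25000 nM, which is a limit of the assay and not a number.

Compound 2, `COc1ccc(C(=O)/C=C/c2cc(OC)c(OC)c(OC)c2)c(O)c1`. In this assay compound 2 gives > 100000 nM, again a limit.

Compound 3, `COc1ccc(O)c(C(=O)/C=C/c2ccc(OC)c(OC)c2)c1`. In this assay compound 3 gives > 50000 nM, also a limit.

All three carry a carbonyl joined through a double bond to a second aromatic ring, but the difference between the core of compound 1 and the core of compound 3 is not broken down here. Compound 1 and compound 2 differ in one place: hydrogen in place of methoxy on an aromatic carbon. The step that the two limits leave unreadable from compound 1 to compound 2 cannot be sized because the limit of > 25000 nM in this assay, at which 1 of the 3 values shown sits, and the limit of > 100000 nM in this assay, at which 1 of the 3 values shown sits, each bound a value without fixing it.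

The same kind of change leads from compound 3 to the unmeasured compound 4, `COc1ccc(/C=C/C(=O)c2cc(OC)ccc2O)cc1`: hydrogen in place of methoxy on an aromatic carbon. The surroundings are not identical, since in the change from compound 1 to compound 2 the site is also para to a hydroxy group, which is not so for the change from compound 3 to compound 4.

Since compound 3 sits at the limit described by the limit of > 50000 nM in this assay, at which 1 of the 3 values shown sits, and the earlier removal of a methoxy left compound 2 at a limit as well, compound 4 is expected to show about no shift in this assay, an estimated step that the limit leaves unreadable from compound 3 to compound 4. The estimated value for compound 4 is therefore 60000 nM, expected to lie somewhere between 15000 nM and 250000 nM, with the assay quite likely reporting only a limit once more.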

Compound 4, half-maximal cytotoxic concentration: > 100000 nM
Compound 4: a limit, no number; the forecaster's own chance of this, stated with the estimate: 75%; at least 1.6-fold (0.22 log units) between middle value and limit.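

Compound 3 and compound 4 each give only a limit in this assay, not a number, so no size can be read for the step between them. The compounds shown leave open the concentration at which any of them would become toxic to these cells, and whether hydrogen in place of methoxy on an aromatic carbon changes that concentration at all.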